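Swapping hydroxy for methylpiperazinyl on compound 3

A few compounds are considered here, and "the series" means these few. Any claim that something is new, unique, unknown or untested is made for them only; others in the source may bear on it.

Compounds in a functional assay on A549 cells (Homo sapiens) for cytotoxicity, read by sulforhodamine B assay; on this read-out higher numbers stand for weaker inhibition and lower numbers for stronger inhibition:
compound 1 `Cc1ccc(-c2cc3ccccc3c(O)n2)cc1` gives 30200 nM
compound 2 `Cc1ccc2c(O)nc(-c3ccccc3)cc2c1` gives 1320 nM
compound 3 `Cc1ccc(-c2cc3cc(C)ccc3c(O)n2)cc1` gives 5620 nM
compound 4 `Cc1ccc(-c2cc3cc(C)ccc3c(N3CCN(C)CC3)n2)cc1` has not yet been measured

Compound 3 stands in the middle of the three numbers, with 5620 nM in this assay. Its nearest neighbour is compound 2, and compound 1 lies furthest away. Two measured steps lead to it, a 5.4-fold lower number from compound 1 to compound 3 (0.73 log units; beyond the scatter) and a 4.3-fold higher number from compound 2 to compound 3 (0.63 log units; beyond the scatter). Each is methyl in place of hydrogen on an aromatic carbon, and they run in opposite directions.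

Compound 4 instead carries 4-methylpiperazin-1-yl in place of hydroxy on an aromatic carbon, next to the ring nitrogen (4-methylpiperazin-1-yl in place of hydroxy on an aromatic carbon). Going by the values given here, no measured compound shows this change, so the two methyl steps offer only a rough guide to size and none to direction. A modest step toward a lower number is tentatively expected, since compound 2 reaches 1320 nM with hydroxy still in place. The expected change is a 3.1-fold lower number from compound 3 to compound 4 (0.49 log units; beyond the scatter). For compound 4 the estimated value is 1800 nM, with an expected range from 400 nM to 8000 nM.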

Compound 4, half-maximal inhibitory concentration: 7240 nM
Compound 4: middle estimate off by 4.0-fold (0.60 log units), on the low side; the range from low to high includes it.
By their numbers in this assay, from the lowest: compound 2; then compounds 3 and 4 (each within the scatter of the next); then compound 1.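

In this assay, placing 4-methylpiperazin-1-yl in place of hydroxy on the aromatic carbon next to the ring nitrogen gives a 1.3-fold higher number from compound 3 to compound 4 (0.11 log units; within the scatter) and is the first change shown at this position. The earlier steps shown here concerned only methyl in place of hydrogen and lay beyond the scatter, whereas this much larger exchange, which removes the hydrogen-bond donor and brings in a six-membered non-aromatic ring, does not separate the two numbers in this one pair. Nothing measured here accounts for this outcome.

As far as these compounds go, it remains open whether a smaller amino group or morpholin-4-yl on this carbon would shift the number. Also open, from the compounds shown here alone, is whether the same exchange would behave alike on the core of compound 2, which gives 1320 nM with hydroxy in place.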